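This account rests on a few compounds, and the source may have more. Where it says the series, first, only, none or still open, it means among the compounds named here.

Measured compounds:
- compound 1, `O=C(Nc1cccc(Cl)c1)C(Cl)Cl`: "not determined" (no result reported)
- compound 2, `N#Cc1cccc(NC(=O)C(Cl)Cl)c1`: 60900 nM

Two compounds share a dichloroacetamide attached to a benzene ring. Among the measured compounds shown here, for compound 1 no number was reported, so compound 2 carries the only value available. In a functional assay on KB cells (Homo sapiens) for antiproliferative activity, read by MTT assay, with a stated time of 72 h (a higher number here means a weaker inhibitor, a lower number a stronger inhibitor), compound 2 gives 60900 nM, a weak result, and with nothing else measured it cannot be ranked against any other compound.

Compound 3, `O=C(Nc1cccc([N+](=O)[O-])c1)C(Cl)Cl`, differs from compound 2 in one place: nitro in place of cyano on an aromatic carbon. For the measured compounds named here, no step between two measured compounds exists that would show what such an exchange does here. With nothing to guide the direction, the expectation is a step of modest size, most likely no larger than the scatter of repeated measurements, in either direction. Compound 3 is therefore expected to give about 50000 nM, within a range of 15000 nM to 150000 nM, which would mean an estimated step of a 1.2-fold lower number from compound 2 to compound 3 (0.09 log units; within the scatter).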

Compound 3, half-maximal inhibitory concentration: 44700 nM
The estimate for compound 3 lay 1.1-fold (0.05 log units) above the measured number, and the stated range covers the measured number.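

Exchanging the cyano group for a nitro group on this aromatic carbon gives, in this assay, a 1.4-fold lower number from compound 2 to compound 3 (0.13 log units; within the scatter), so the two compounds cannot be told apart in this test. Among the compounds shown here, this is the first direct comparison at this position, and it shows that two different groups, with the nitro group having more heavy atoms and more hydrogen-bond acceptors, can stand here with no difference beyond ordinary measurement scatter. No measurement shown here offers a reason for this similarity.

Going by these compounds, neither group carries a hydrogen-bond donor or a net charge, so it remains open whether an amine, a carboxylic acid or a longer chain in the same place would shift the number. Compound 1, with its chlorine, has no result and adds nothing to this comparison.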